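Swapping the amide cap on a shared core: compound 4

The source may report more compounds than this note shows. Statements on the series, on what has been measured and on what is new or still open speak of the compounds shown alone.

Measured so far in a functional assay on MCF7 cells (Homo sapiens) for cytotoxicity, read by MTT assay, with a stated time of 72 h; a lower number here means a stronger inhibitor, a higher number a weaker inhibitor:
- compound 1 `CN1[C@@H]2c3[nH]c4ccccc4c3C[C@H]1[C@H](C#N)N1[C@@H](CNC(=O)c3cccc(C(F)(F)F)c3)c3[nH]c4ccccc4c3C[C@@H]21` gives 110 nM
- compound 2 `CN1[C@@H]2c3[nH]c4ccccc4c3C[C@H]1[C@H](C#N)N1[C@@H](CNC(=O)c3cc4ccccc4s3)c3[nH]c4ccccc4c3C[C@@H]21` gives 3180 nM
- compound 3 `CN1[C@@H]2c3[nH]c4ccccc4c3C[C@H]1[C@H](C#N)N1[C@@H](CNC(=O)c3cc4ccccc4o3)c3[nH]c4ccccc4c3C[C@@H]21` gives 320 nM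

All three compounds share one core and differ only in the group attached to the amide carbonyl carbon. Compound 1 stands lowest of the three numbers, which in this assay means the strongest inhibitor among them; compound 3 is nearest to it, and compound 2 is furthest away.

Compound 4 `CN1[C@@H]2c3[nH]c4ccccc4c3C[C@H]1[C@H](C#N)N1[C@@H](CNC(=O)/C=C/c3ccccc3)c3[nH]c4ccccc4c3C[C@@H]21` has not yet been measured. It differs from compound 1 in this way: 2-phenylethenyl in place of 3-(trifluoromethyl)phenyl on a carbonyl carbon

The two steps that bear on this change both replace the same 3-(trifluoromethyl)phenyl group on the carbonyl carbon. Both moved the number upward: a 29-fold higher number from compound 1 to compound 2 (1.46 log units; beyond the scatter) and a 2.9-fold higher number from compound 1 to compound 3 (0.46 log units; beyond the scatter). Neither replacement matched the 2-phenylethenyl group of compound 4, so the direction is taken from those steps while the size stays uncertain. On that basis compound 4 is expected to give a higher number than compound 1 in this assay, with a step of about a 3.2-fold higher number from compound 1 to compound 4 (0.50 log units; beyond the scatter). The estimate for compound 4 is 350 nM, with an expected range from 110 nM to 1500 nM.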

Compound 4, half-maximal inhibitory concentration: 7190 nM
Estimate against measurement, compound 4: 21-fold (1.31 log units) below; measured number above the stated range.
By their numbers in this assay, from the lowest: compound 1; then compound 3; then compound 2; then compound 4.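

Compound 4 keeps the one six-membered aromatic ring of carbon that compound 1 also carries, yet in this assay the change gives a 65-fold higher number from compound 1 to compound 4 (1.82 log units; beyond the scatter) and so having that ring on this carbonyl carbon is not enough to keep the number low. The 2-phenylethenyl group is also the weakest of the four groups tried here, as shown by a 22-fold higher number from compound 3 to compound 4 (1.35 log units; beyond the scatter) and by a 2.3-fold higher number from compound 2 to compound 4 (0.35 log units; beyond the scatter) and the range at this one position now extends beyond what the first three compounds showed. Nothing available here explains why these groups differ so strongly.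

Compound 4 differs from compound 1 by both losing the trifluoromethyl group and gaining a double bond outside the aromatic ring, and the compounds shown leave open which of these changes matters more. From the compounds shown here alone, a plain phenyl group or a saturated 2-phenylethyl group on the same carbonyl carbon would help to separate the two, while the effect of an amine or a carboxylic acid in this group also remains unknown.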